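The source may report more compounds than this note shows. Statements on the series, on what has been measured and on what is new or still open speak of the compounds shown alone.

Going by the values given here, in a functional assay on QGY-7703 cells (Homo sapiens) for cytotoxicity, read by MTT assay, with a stated time of 24 h (on this read-out higher numbers stand for weaker inhibition and lower numbers for stronger inhibition), compound 1 (`COc1cc(/C=C2\CN(C)C/C(=C\c3cccnc3)C2=O)cc(OC)c1OC`) gives 4300 nM and compound 2 (`O=C1/C(=C/c2cccnc2)CN(S(=O)(=O)c2ccccc2)C/C1=C\c1ccccc1F`) gives 4800 nM on the numbers so far. These two values lie within the scatter of each other, so compound 2 has no rank against compound 1. Among the compounds with values here, no measured pair differs in one place only, and the data therefore give no direct guide to the size of the next step.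

Compound 3 (`N#Cc1ccc(S(=O)(=O)N2C/C(=C\c3cccnc3)C(=O)/C(=C/c3ccccc3F)C2)cc1`) differs from compound 2 by one change (cyano in place of hydrogen on an aromatic carbon) on the phenylsulfonyl group: cyano in place of hydrogen on an aromatic carbon, para to a large group, giving (4-cyanophenyl)sulfonyl. Within the data shown here, with no measured step to lean on, the expectation in this assay is a small move toward stronger inhibition that may not clear the scatter. The estimate takes compound 2 at 4800 nM as its anchor. The expected change is a 1.4-fold lower number from compound 2 to compound 3 (0.14 log units; within the scatter) and remains small. For compound 3 the estimated value is 3500 nM within an expected range of 1500 nM to 8000 nM in this series.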

Compound 3, half-maximal inhibitory concentration: 15800 nM
The estimate for compound 3 lay 4.5-fold (0.65 log units) below the measured number; the measured number lies above the stated range.
By their numbers in this assay, from the lowest: compounds 1 and 2 (each within the scatter of the next); then compound 3.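

Going by these compounds alone, on the phenylsulfonyl group, the place para to a large group responds to substitution in this assay: cyano in place of hydrogen on an aromatic carbon gives a 3.3-fold higher number from compound 2 to compound 3 (0.52 log units; beyond the scatter) and provides the first comparison that differs in one place only. Phenyl to 4-cyanophenyl on the sulfonyl is therefore not a neutral exchange here, and its direction is toward weaker inhibition, something compound 1 and compound 2 could not show as they differ in more than one place. Nothing available on this series accounts for the size or direction of this step.

From the compounds shown here alone, whether the weaker inhibition is particular to cyano or would also follow other groups at this place remains open, and an amine, a carboxylic acid or a methoxy group on the same aromatic carbon would help to separate these cases. Going by these compounds, the step also rests on a single pair, so it remains unknown whether it would hold with chlorine or an amine in place of the fluorine on the fluorophenyl ring.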